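Butyl in place of methyl on the ring amine of compound 3

A few compounds are considered here, and "the series" means these few. Any claim that something is new, unique, unknown or untested is made for them only; others in the source may bear on it.

Compound 3 `COc1ccc2c(c1)c(C1=CCN(C)CC1)cn2S(=O)(=O)c1ccc2cccnc2c1` gives 82 nM in an assay on HEK293 cells for displacement of a labelled ligand from 5-hydroxytryptamine receptor 6 (Homo sapiens), read by scintillation counting (a lower number here means a stronger inhibitor, a higher number a weaker inhibitor), the highest number among the three measured compounds and beyond the scatter from each of the others. Compound 1 `Cc1c(C2=CCNCC2)c2ccccc2n1S(=O)(=O)c1ccc2cccnc2c1` gives 18 nM and compound 2 `COc1ccc2c(c1)c(C1CCNCC1)cn2S(=O)(=O)c1ccc2cccnc2c1` gives 30 nM in this assay. Among the compounds with values here, the only step between compounds differing in one place is a 2.7-fold higher number from compound 2 to compound 3 (0.44 log units; beyond the scatter), which sets a methyl-bearing unsaturated ring amine in place of the unsubstituted saturated one; it is the sole measured change touching the ring amine. Compound 4 `CCCCN1CC=C(c2cn(S(=O)(=O)c3ccc4cccnc4c3)c3ccc(OC)cc23)CC1` carries propyl in place of hydrogen on a saturated chain carbon bound to an amine nitrogen in a ring. Within the data shown here, no measured pair varies the substituent on this amine nitrogen beyond methyl, so the step to compound 4 has no direct anchor; the measured series only shows that growth at this amine, in the step from compound 2 to compound 3, went with a higher number. A modest further rise is therefore expected, with wide uncertainty. For compound 4 the expected value in this assay is 200 nM, within 60 nM to 700 nM, which means an expected step of a 2.4-fold higher number from compound 3 to compound 4 (0.39 log units; beyond the scatter).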

Compound 4, inhibition constant: 219 nM
Compound 4: the middle estimate sits 1.1-fold (0.04 log units) below what was measured; measured number inside the range.
By their numbers in this assay, from the lowest: compounds 1 and 2 (each within the scatter of the next); then compound 3; then compound 4.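

In (this assay), the ring amine now carries a chain longer than methyl, and butyl in place of methyl raises the number (a 2.7-fold higher number from compound 3 to compound 4 (0.43 log units; beyond the scatter)). This separates a change in chain length alone from the earlier step (a 2.7-fold higher number from compound 2 to compound 3 (0.44 log units; beyond the scatter)), which changed both the substituent on the amine and the ring itself; the two steps are printed at nearly the same size, and together they span (a 7.3-fold higher number from compound 2 to compound 4 (0.86 log units; beyond the scatter)). Nothing measured here explains the rise.

On these data alone, whether the number keeps climbing with a longer chain such as hexyl, or changes with a benzyl or hydroxyethyl group on this amine, remains open. Also open, as far as these compounds go, is whether butyl has a comparable effect on the saturated ring amine of compound 2 or on the core of compound 1.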